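Homologation of the piperidine amide and the alpha-1 binding

This account rests on a few compounds, and the source may have more. Where it says the series, first, only, none or still open, it means among the compounds named here.

Measured compounds:
compound 1 `CCNC(=O)C1CCN(c2nc(N)c3cc(OC)c(OC)cc3n2)CC1` gives 1.64 nM
compound 2 `CCCNC(=O)CC1CCN(c2nc(N)c3cc(OC)c(OC)cc3n2)CC1` gives 0.65 nM

Of the compounds shown here, two sharing the same core have been measured in an assay on isolated protein for displacement of a labelled ligand from Adrenergic receptor alpha-1 (Rattus norvegicus); a higher number here means a weaker inhibitor, a lower number a stronger inhibitor. Compound 1 gives 1.64 nM in this assay, which is the higher of the two numbers; compound 2 gives 0.65 nM. Going by the values given here, the one measured step, a 2.5-fold lower number from compound 1 to compound 2 (0.40 log units; beyond the scatter), accompanies the change from ethylcarbamoyl to (propylcarbamoyl)methyl on a saturated ring carbon.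

Compound 3 `COc1cc2nc(N3CCC(CC(=O)NCC4CC4)CC3)nc(N)c2cc1OC` has not yet been measured in this assay. It differs from compound 1 as follows: ((cyclopropylmethyl)carbamoyl)methyl in place of ethylcarbamoyl on a saturated ring carbon

Among the compounds with values here, the only step that bears on this change is a 2.5-fold lower number from compound 1 to compound 2 (0.40 log units; beyond the scatter), since compound 2 and compound 3 both carry a carbamoylmethyl group on the saturated ring carbon and differ only in the alkyl on the amide nitrogen, propyl against cyclopropylmethyl. Within the data shown here, the step from compound 1 to compound 3 is therefore expected to resemble the one to compound 2, giving a modestly lower number, namely a 2.3-fold lower number from compound 1 to compound 3 (0.37 log units; beyond the scatter). Compound 3 is thus estimated to give 0.7 nM in this assay, within a range of 0.3 nM to 1.6 nM.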

Compound 3, inhibition constant: 1.08 nM
Compound 3: middle estimate off by 1.5-fold (0.19 log units), on the low side, and the stated range covers the measured number.
By their numbers in this assay, from the lowest: compounds 2, 3 and 1 (each within the scatter of the next, the first and the last beyond it).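

In this assay the change to ((cyclopropylmethyl)carbamoyl)methyl on the saturated ring carbon gives a 1.5-fold lower number from compound 1 to compound 3 (0.18 log units; within the scatter) and so cannot be told apart from no change at this position, whereas the step to compound 2 lay beyond the scatter. The exchange of ethyl for cyclopropyl on the saturated chain carbon bound to the amide-type nitrogen gives a 1.7-fold higher number from compound 2 to compound 3 (0.22 log units; within the scatter) and shows that this position accepts a three-membered ring of carbon without a difference that can be read, so compound 2 and compound 3 stand level here. Nothing measured on hand accounts for these numbers.

The compounds shown leave open whether the carbamoylmethyl link or the alkyl on the amide nitrogen carries the step from compound 1 to compound 2, since no pair shown separates the two. They also leave open what a benzyl group or a longer chain such as hexyl on the amide nitrogen, or a carboxylic acid in place of the amide, would do in this assay to the number at this position.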